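The source may report more compounds than this note shows. Statements on the series, on what has been measured and on what is new or still open speak of the compounds shown alone.

Compound 1 `COc1ccc(C2=C(c3cc(OC)c(OC)c(OC)c3)C(=O)C(OC(C)=O)C2)cc1OC(C)C`: > 100 ug/mL
Compound 2 `COc1cc(C2=C(c3cc(C)c(OC)c(C)c3)C(O)CC2=O)cc(OC)c1OC`: > 100 ug/mL
Compound 3 `COc1cc(C2=C(c3ccc(OCC(=O)O)cc3)C(O)CC2=O)cc(OC)c1OC`: "not determined" (no result reported)

In an ADME assay on HT-29 cells (Homo sapiens) for cytotoxicity, read by MTT assay, with a stated time of 72 h (a lower number here means a stronger inhibitor, a higher number a weaker inhibitor), compound 3 has no number to stand on, as its entry reads "not determined" (no result reported). Compound 1 gives > 100 ug/mL, which is a limit of the assay and not a number. Compound 2 gives > 100 ug/mL, which is also a limit.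

Compound 4 `CCOC(=O)COc1ccc(C2=C(c3cc(OC)c(OC)c(OC)c3)C(=O)CC2O)cc1` has yet to be measured. It differs by a single change: ethyl in place of hydrogen on an oxygen next to a carbonyl group. Ethyl takes the place of hydrogen on an oxygen next to a carbonyl group, so carboxymethyl becomes (ethoxycarbonyl)methyl.

Compound 3 offers no number to step from, so no size of step can be read from the data in this assay, and none beyond the scatter is expected in either direction. Compound 4 is expected to stay in the same region as compound 1 and compound 2 because of the limit of > 100 ug/mL in this assay, at which 2 of the 3 values shown sit. A reported limit instead of a number is quite possible. For compound 4 the estimated value is 80 ug/mL, with an expected range of 15 ug/mL to 200 ug/mL.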

Compound 4, half-maximal inhibitory concentration: > 100 ug/mL
Compound 4: a limit, no number; the forecaster's own chance of this, stated with the estimate: 60%; middle value at least 1.2-fold (0.09 log units) away from the limit.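

Compound 3 has no reported result and compound 4 gives only a limit, not a number, so no step can be read between them. The compounds shown leave open whether ethyl in place of hydrogen changes anything in this assay, and how strongly any of these compounds acts there.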